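Losing the amino group: compound 3 to compound 4

The compounds below may be only part of what the source reports. "The series", "measured", "known", "first", "only" and "open" are said of these compounds alone.

Compound 1 `CC(C)(C)n1cc2c(n1)C(=O)CC1(CCN(C(=O)c3cc(-c4ccccc4)nc4ccccc34)CC1)O2` gives > 10000 nM (a limit)
Compound 2 `CC(C)(C)n1cc2c(n1)C(=O)CC1(CCN(C(=O)c3cc(-c4ccc(Br)cc4)nc4ccccc34)CC1)O2` gives > 10000 nM (a limit)
Compound 3 `CC(C)(C)n1cc2c(n1)C(=O)CC1(CCN(C(=O)c3cc(-c4ccc(N)cc4)nc4ccccc34)CC1)O2` gives 4960 nM

These values come from a functional assay on MDA-MB-231 cells (Homo sapiens) for inhibition, read by MTT assay, with a stated time of 72 h; on this read-out higher numbers stand for weaker inhibition and lower numbers for stronger inhibition. Going by the values given here, compound 3 holds the only number, and the other two values are limits. The next structure is compound 4 `CC(C)(C)n1cc2c(n1)C(=O)CC1(CCN(C(=O)c3cc(-c4ccccn4)nc4ccccc34)CC1)O2`, with pyridin-2-yl in place of 4-aminophenyl on an aromatic carbon next to the ring nitrogen: pyridin-2-yl in place of 4-aminophenyl on an aromatic carbon. Among the compounds with values here, two steps bear on this change: an at least 2.0-fold lower number from compound 1 to compound 3 (0.30 log units; that floor lies within the scatter) and an at least 2.0-fold lower number from compound 2 to compound 3 (0.30 log units; that floor lies within the scatter). Both are floors within the scatter, so the support is thin. Compound 4 lacks the amino group, as do the two compounds at the limit: the limit of > 10000 nM in this assay, at which 2 of the 3 values shown sit. A move towards weaker inhibition is therefore expected, estimated as a 2.4-fold higher number from compound 3 to compound 4 (0.38 log units; beyond the scatter). The estimate for compound 4 is 12000 nM, with an expected range of 5000 nM to 30000 nM.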

Compound 4, half-maximal inhibitory concentration: 8100 nM
The estimate for compound 4 lay 1.5-fold (0.17 log units) above the measured number; the measured number falls inside the stated range.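

In this assay, pyridin-2-yl in place of 4-aminophenyl removes the hydrogen-bond donor and leaves the number within the scatter, so a number short of the limit at this position does not rest on the amino group: a 1.6-fold higher number from compound 3 to compound 4 (0.21 log units; within the scatter). Against the phenyl and 4-bromophenyl compounds only floors within the scatter can be read: an at least 1.2-fold lower number from compound 1 to compound 4 (0.09 log units; that floor lies within the scatter) and an at least 1.2-fold lower number from compound 2 to compound 4 (0.09 log units; that floor lies within the scatter). Compound 1 and compound 2 remain limits, not numbers: the limit of > 10000 nM in this assay, at which 2 of the 4 values shown sit.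

Open, as far as these compounds go, is whether a hydroxyl or a dimethylamino group on the phenyl ring would move the number in this assay beyond the scatter.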